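Adding One Carbon to the Chain of Compound 2

This account rests on a few compounds, and the source may have more. Where it says the series, first, only, none or still open, it means among the compounds named here.

In a functional assay on A549 cells (Homo sapiens) for antiproliferative activity, read by MTT assay, with a stated time of 72 h (on this read-out higher numbers stand for weaker inhibition and lower numbers for stronger inhibition), compound 1 (`C=CC(=O)Nc1cccc(Oc2nc(Nc3ccn(C)n3)nc3c2CSCC3)c1`) gives 18600 nM as its half-maximal inhibitory concentration. Compound 2 (`C/C=C/C(=O)Nc1cccc(Oc2nc(Nc3ccn(C)n3)nc3c2CSCC3)c1`) stands at > 50000 nM and this is a limit, not a number. Compound 3 (`CC/C=C/C(=O)Nc1cccc(Oc2nc(Nc3ccn(C)n3)nc3c2CSCC3)c1`) differs from it by methyl in place of hydrogen on a saturated chain carbon bound to a double-bonded chain carbon with methyl in place of hydrogen on a saturated chain carbon bound to a double-bonded chain carbon, so prop-1-en-1-yl becomes but-1-en-1-yl. Within the data shown here, the only measured step that bears on this is an at least 2.6-fold higher number from compound 1 to compound 2 (0.42 log units; beyond the scatter) where the chain on the carbonyl carbon also grew. A further small move towards weaker inhibition is therefore expected in this assay with no recovery. The expected change is a step that the limit leaves unreadable from compound 2 to compound 3 in size. Compound 3 is estimated at 70000 nM with a range from 35000 nM to 150000 nM and may again yield only a limit.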

Compound 3, half-maximal inhibitory concentration: 36800 nM
For compound 3 the middle estimate is 1.9-fold (0.28 log units) above the measured one; low and high end bracket the measured number.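

Methyl in place of hydrogen on a saturated chain carbon bound to a double-bonded chain carbon does not push the number further up in this assay, as the step shows: an at least 1.3-fold lower number from compound 2 to compound 3 (0.13 log units; that floor lies within the scatter). With but-1-en-1-yl in place of vinyl on the carbonyl carbon, the longer chain stays close to the shorter one, with a 2.0-fold higher number from compound 1 to compound 3 (0.30 log units; within the scatter). The reading for compound 2 is a limit and not a number, so the true size of the first step stays unknown: the limit of > 50000 nM in this assay, at which 1 of the 3 values shown sits.

As far as these compounds go, what a still longer chain, or a chain carrying an amine, on the carbonyl carbon would give remains open.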